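The source may report more compounds than this note shows. Statements on the series, on what has been measured and on what is new or still open speak of the compounds shown alone.

Measured compounds:
compound 1 `COc1cc2c(cc1OC)CN(S(=O)(=O)c1ccc(-n3cc(COc4ccccc4C(C)=O)nn3)cc1)CC2` — > 50 ug/mL
compound 2 `Cc1ccc(OCc2cn(-c3ccc(S(=O)(=O)N4CCc5ccccc5C4)cc3)nn2)cc1` — > 50 ug/mL

In a functional assay on MOLT-3 cells (Homo sapiens) for cytotoxicity, read by MTT assay, with a stated time of 48 h (on this read-out lower numbers stand for stronger inhibition and higher numbers for weaker inhibition), compound 1 gives > 50 ug/mL, which is a limit of the assay and not a number. Compound 2 in this assay gives > 50 ug/mL, likewise a limit. Compound 3 `COc1cc2c(cc1OC)CN(S(=O)(=O)c1ccc(-n3cc(COc4ccccc4)nn3)cc1)CC2` differs from compound 1 by hydrogen in place of acetyl on an aromatic carbon. For the measured compounds named here, no measured pair shows this change, and because the limit of > 50 ug/mL in this assay, at which 2 of the 2 values shown sit, both measured values stand at the same point, the step expected is a number no higher from compound 1 to compound 3 (the limit leaves the size open), none beyond the scatter. Compound 3 is therefore expected near 50 ug/mL, between 20 ug/mL and 120 ug/mL, most probably reported again as a limit.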

Compound 3, half-maximal inhibitory concentration: > 50 ug/mL
Compound 3: no number, only a limit; the forecaster's own chance of this, stated with the estimate: 75%; the middle value sits exactly at the limit.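

Compound 1 and compound 3 both stand at a limit in this assay, so no step can be read between them. What hydrogen in place of acetyl does here stays open, as does any ranking of the three compounds: the limit of > 50 ug/mL in this assay, at which 3 of the 3 values shown sit.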